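This account rests on a few compounds, and the source may have more. Where it says the series, first, only, none or still open, it means among the compounds named here.

Measured compounds:
- compound 1 `CC1=C(C(=O)NC(C)C)C(c2cccs2)NC(=O)N1` gives 1%
- compound 2 `CCC(C)OC(=O)C1=C(C)NC(=O)NC1c1ccco1` gives 3%

Both numbers come from an assay on membranes from HeLa cells for displacement of a labelled ligand from adenosine receptor A3 (Homo sapiens), read by scintillation counting, with a stated time of 180 min, tested at 1 uM; on this read-out higher numbers stand for more inhibition at the one concentration tested (going by the name of the read-out) and lower numbers for less inhibition. Compound 2 gives 3% and compound 1 gives 1% in this assay, and the two values lie within the scatter of each other, so neither can be said to inhibit more than the other. Both sit close to no inhibition at all.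

Compound 3 `CCC(C)OC(=O)C1=C(C)NC(=O)NC1c1cccs1` has not yet been measured. It is built from compound 2 by one change: thiophen-2-yl in place of furan-2-yl on a saturated ring carbon. The thiophen-2-yl group is already present in compound 1, though compound 1 differs from compound 2 in more than one place, so no single-change comparison is available for this swap.

With both measured values near zero and no step beyond the scatter anywhere in this small set, the step from compound 2 to compound 3 is expected to be small, no change at the digits printed from compound 2 to compound 3 (within the scatter), with no clear direction. Compound 3 is therefore estimated to give 3% in this assay, expected to fall between -5% and 12%.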

Compound 3, a percentage reported as inhibition, at one concentration (the size of the read-out at that concentration, not a potency): 7%
Estimate against measurement, compound 3: 4 percentage points below; low and high end bracket the measured number.
By their numbers in this assay, from the lowest: compounds 1, 2 and 3 (each within the scatter of the next).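

In this assay, among the compounds shown here, the first single-change comparison at this position, thiophen-2-yl in place of furan-2-yl on a saturated ring carbon, gives a number 4 percentage points higher from compound 2 to compound 3 (within the scatter) and so does not separate the two five-membered aromatic rings, which differ here only in having sulfur or oxygen as the ring hetero atom. On the carbonyl carbon, sec-butoxy in place of isopropylamino gives a number 6 percentage points higher from compound 1 to compound 3 (within the scatter) with thiophen-2-yl kept in place, so this ester-for-amide exchange cannot be told apart from no change either, and all three compounds still read close to no inhibition at the one concentration tested. No separate measurement is available to help interpret these small differences.

For the compounds shown here, with every step inside the scatter, these compounds show only that neither change moves the reading measurably, and they do not show which parts of the structure, if any, matter for this receptor. On these data alone, whether a phenyl ring in place of thiophen-2-yl, or a longer chain such as hexyloxy in place of sec-butoxy, would produce a step beyond the scatter remains open.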